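Acetyl in Place of Methyl on the Thiolane Ring

The source may hold more compounds than are shown below. What is called first, only, known or untested is meant among the compounds shown, and "the series" means these compounds.

Going by the values given here, compound 2 `CC1CCC(C2=CCC(N(CCN3CCCC3)C(=O)Nc3ccc(F)c(Cl)c3)CC2)S1` holds the higher of the two numbers known so far: in a functional assay for antagonist activity at melanin-concentrating hormone receptor 1 (Homo sapiens) (on this read-out lower numbers stand for stronger inhibition and higher numbers for weaker inhibition), compound 2 gives 84.9 nM, while compound 1 `CC(C)N(CCN(C(=O)Nc1cccc(C#N)c1)C1CC[C@]2(c3cccc(C#N)c3)CC2C1)C(C)C` gives 7.6 nM, a gap beyond the usual scatter. Compound 3 `CC(=O)C1CCC(C2=CCC(N(CCN3CCCC3)C(=O)Nc3ccc(F)c(Cl)c3)CC2)S1` is reached from compound 2 by a single change, (acetyl in place of methyl on a saturated ring carbon), acetyl in place of methyl on a saturated ring carbon. Among the compounds with values here, no measured pair shows this change, so its size is unknown. The expected 1.1-fold higher number from compound 2 to compound 3 (0.03 log units; within the scatter) is of no size beyond the scatter, in either direction. Compound 3 is thus estimated at 90 nM, ranging from 30 nM to 270 nM.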

Compound 3, inhibition constant: 31 nM
Beside the measured number, compound 3's estimate is 2.9-fold (0.46 log units) above it; measured number inside the range.
By their numbers in this assay, from the lowest: compound 1; then compound 3; then compound 2.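

Going from the 5-methylthiolan-2-yl to the 5-acetylthiolan-2-yl group in this assay, the step is a 2.7-fold lower number from compound 2 to compound 3 (0.44 log units; beyond the scatter) and counts as modest. This saturated ring carbon next to the ring sulfur therefore accepts the larger acetyl, with its added hydrogen-bond acceptor, and inhibition gets stronger rather than weaker. No evidence at hand accounts for this gain.

As far as these compounds go, whether the carbonyl or the extra carbon matters remains open, since an ethyl, a hydroxyethyl or a carboxylic acid on this carbon could separate the two. From the compounds shown here alone, how a longer chain such as propanoyl would read in this assay is also open.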